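Swapping methoxy for chloro on the phenyl ring

The source may report more compounds than this note shows. Statements on the series, on what has been measured and on what is new or still open speak of the compounds shown alone.

Measured compounds:
- compound 1 `NS(=O)(=O)NCCC1CCN(c2cc(-c3ccccc3)ncn2)CC1`: 53200 nM
- compound 2 `CCCCc1ccc(-c2cc(N3CCC(CCNS(N)(=O)=O)CC3)ncn2)cc1`: 11300 nM
- compound 3 `COc1ccc(-c2cc(N3CCC(CCNS(N)(=O)=O)CC3)ncn2)cc1`: 56600 nM

All three share one core and differ only in the group on the phenyl ring. In a functional assay on MCF7 cells (Homo sapiens) for antiproliferative activity, read by sulforhodamine B assay, with a stated time of 48 h (a lower number here means a stronger inhibitor of growth, a higher number a weaker inhibitor of growth), compound 3 gives 56600 nM. Its number and that of compound 1 lie within the scatter of each other, as the step of a 1.1-fold higher number from compound 1 to compound 3 (0.03 log units; within the scatter) shows, so nothing separates them. Within the data shown here, compound 2 stands apart: the steps of a 4.7-fold lower number from compound 1 to compound 2 (0.67 log units; beyond the scatter) and a 5.0-fold higher number from compound 2 to compound 3 (0.70 log units; beyond the scatter) are both beyond the scatter, and they are the only steps here that clear it.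

Compound 4 `NS(=O)(=O)NCCC1CCN(c2cc(-c3ccc(Cl)cc3)ncn2)CC1` is not yet measured. It arises from compound 3 by chloro in place of methoxy on an aromatic carbon. Among the measured compounds shown here, no measured step exchanges methoxy for chloro, so the bearing steps are only indirect: the methoxy-for-hydrogen step brought no change, while the butyl-for-methoxy step lowered the number modestly. A small step in this assay is therefore plausible, its direction uncertain. Compound 4 is estimated at 30000 nM (range 7000 nM to 100000 nM), a step of a 1.9-fold lower number from compound 3 to compound 4 (0.28 log units; within the scatter) expected from compound 3.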

Compound 4, concentration for 50% growth inhibition: 19700 nM
Compound 4: middle estimate off by 1.5-fold (0.18 log units), on the high side, and the stated range covers the measured number.
By their numbers in this assay, from the lowest: compounds 2 and 4 (each within the scatter of the next); then compounds 1 and 3 (each within the scatter of the next).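

In this assay, the position para to a large group now shows that a single chlorine can match butyl, since the step (a 1.7-fold higher number from compound 2 to compound 4 (0.24 log units; within the scatter)) stays within the scatter. Chloro also separates clearly from hydrogen (a 2.7-fold lower number from compound 1 to compound 4 (0.43 log units; beyond the scatter)) and from methoxy (a 2.9-fold lower number from compound 3 to compound 4 (0.46 log units; beyond the scatter)), so the number does not simply follow the count of heavy atoms: methoxy, with more of them than chloro, stays level with hydrogen. Nothing measured here gives a reason for this difference between the groups.

Still open, on these data alone, is how an amine, a carboxylic acid or a chain longer than butyl would read at this position. Also open, as far as these compounds go, is whether chloro would give a similar number at another place on the phenyl ring.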